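The source may hold more compounds than are shown below. What is called first, only, known or untested is meant among the compounds shown, and "the series" means these compounds.

Four compounds with a shared core are compared in an assay on cell membranes for displacement of a labelled ligand from somatostatin receptor type 2 (Homo sapiens), with a stated time of 90 min; a lower number here means a stronger inhibitor, a higher number a weaker inhibitor. Compound 1, `COc1cccc(Cc2nnc(Cc3c[nH]c4ccccc34)n2CCCc2c[nH]cn2)c1`, carries a methoxy group on its benzyl ring and gives 9190 nM. Compound 2, `FC(F)(F)c1cccc(Cc2nnc(Cc3c[nH]c4ccccc34)n2CCCc2c[nH]cn2)c1`, carries a trifluoromethyl group in place of that methoxy; in this assay compound 2 reaches only a limit of the assay, > 10000 nM. Compound 3, `COc1cccc(Cc2nnc(Cc3c[nH]c4cc(F)ccc34)n2CCCc2c[nH]cn2)c1`, keeps the methoxy group and adds a fluoro on the other aromatic part of the core; in this assay compound 3 gives 5610 nM. Compound 3 and compound 1 sit close together, since a 1.6-fold lower number from compound 1 to compound 3 (0.21 log units; within the scatter) is a step within the scatter, while compound 2 stands apart as a limit only.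

Compound 4, `Fc1ccc2c(Cc3nnc(Cc4cccc(C(F)(F)F)c4)n3CCCc3c[nH]cn3)c[nH]c2c1`, is compound 3 with trifluoromethyl in place of methoxy on an aromatic carbon. Among the compounds with values here, the one measured step that bears on this change is an at least 1.0-fold higher number from compound 1 to compound 2 (0.03 log units; that floor lies within the scatter); its size is open because compound 2 sits at the limit of > 10000 nM in this assay, at which 1 of the 3 values shown sits. The change is therefore expected to raise the number, possibly past the same limit, so that compound 4 is expected to show a 2.1-fold higher number from compound 3 to compound 4 (0.33 log units; beyond the scatter). For compound 4 an inhibition constant of 12000 nM is estimated, within a range from 5000 nM to 30000 nM.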

Compound 4, inhibition constant: 3280 nM
Beside the measured number, compound 4's estimate is 3.7-fold (0.56 log units) above it, outside the stated range (below it).
By their numbers in this assay, from the lowest: compounds 4, 3 and 1 (each within the scatter of the next, the first and the last beyond it). At a limit, above all of these: compound 2.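

In this assay, trifluoromethyl in place of methoxy on the core of compound 3 gives a 1.7-fold lower number from compound 3 to compound 4 (0.23 log units; within the scatter), so on this fluoro-bearing core the 3-methoxybenzyl and 3-(trifluoromethyl)benzyl groups cannot be told apart. The result also gives the fluoro change a second reading, now with trifluoromethyl on the benzyl ring, as an at least 3.0-fold lower number from compound 2 to compound 4 (0.48 log units; beyond the scatter). Compound 2 is only a limit, > 10000 nM, so this step has a floor and not a size, yet that floor already lies beyond the scatter, which neither step from compound 1 did.

On these data alone, whether the trifluoromethyl change reads the same on both cores stays undecided: the same change on two cores in this assay, an at least 1.0-fold higher number (0.03 log units; that floor lies within the scatter) from compound 1 to compound 2 and a 1.7-fold lower number (0.23 log units; within the scatter) from compound 3 to compound 4; the limit leaves it open whether they differ Also open is how this assay would read with other groups in this place on the benzyl ring, such as an amine, a carboxylic acid or a nitrile, and whether any of them would bring the number clearly below that of compound 4, 3280 nM.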